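The source may hold more compounds than are shown below. What is called first, only, known or untested is meant among the compounds shown, and "the series" means these compounds.

Working notes on the series.

For compound 1 `COc1ccc(-c2cs/c(=N/NC(=O)CSc3nnnn3-c3ccccc3)n2-c2ccccc2)cc1` the result in a functional assay on C6 cells (Rattus norvegicus) for cytotoxicity, read by MTT assay, with a stated time of 24 h (a lower number here means a stronger inhibitor, a higher number a weaker inhibitor), is "not determined" (no result reported). Compound 2 `COc1ccc(-c2cs/c(=N/NC(=O)CSc3nnc(C)s3)n2-c2ccccc2)cc1` gives 18.7 ug/mL in this assay. For the measured compounds named here, compound 3 `Cc1ccc(-c2cs/c(=N/NC(=O)CSc3ncccn3)n2-c2ccccc2)cc1` gives 85 ug/mL in this assay, which is the higher of the two numbers so far: set against compound 2 it sits clearly beyond the scatter, at the weaker end of what has been measured. Compound 2 and compound 3 differ in more than one place. That pair isolates no single change.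

Compound 4 `COc1ccc(-c2cs/c(=N/NC(=O)CSc3ncccn3)n2-c2ccccc2)cc1` is not yet measured. It differs from compound 3 by one change: methoxy in place of methyl on an aromatic carbon. The rest of the molecule, including the heteroaryl thioether on the acyl side, is kept. Going by the values given here, no pair of measured compounds isolates this change, so the size of the step is open. Among the compounds with values here, the one hint is that compound 2, the only methoxy-bearing compound with a number, gives 18.7 ug/mL, the lower figure, while the methyl-bearing compound 3 gives the higher one; but that pair also differs elsewhere.

For compound 4 the step in this assay is expected to be a 1.5-fold lower number from compound 3 to compound 4 (0.19 log units; within the scatter), towards a somewhat lower number, but possibly within the scatter. Compound 4 is expected to give about 55 ug/mL, in the range 20 ug/mL to 150 ug/mL.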

Compound 4, half-maximal inhibitory concentration: 102 ug/mL
Compound 4: middle estimate off by 1.9-fold (0.27 log units), on the low side; the measured number falls inside the stated range.
By their numbers in this assay, from the lowest: compound 2; then compounds 3 and 4 (each within the scatter of the next).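

In this assay, the change from 4-methylphenyl to 4-methoxyphenyl, with pyrimidin-2-yl kept on the sulfur, gives a 1.2-fold higher number from compound 3 to compound 4 (0.08 log units; within the scatter), so this position, para to a large group, does not separate methoxy from methyl in this setting. For the compounds shown here, with methoxy held constant, pyrimidin-2-yl in place of 5-methyl-1,3,4-thiadiazol-2-yl on the sulfur gives a 5.5-fold higher number from compound 2 to compound 4 (0.74 log units; beyond the scatter), which is the first single-place change to clear the scatter and points to the group on the sulfur, rather than the methoxy group, as the place where the number moves. Nothing available bears on the reason for either result.

Going by these compounds alone, whether methoxy and methyl also match when 5-methyl-1,3,4-thiadiazol-2-yl sits on the sulfur remains open, as the single methyl and methoxy pair carries pyrimidin-2-yl. The compounds shown also leave open how a chlorine atom, a hydroxyl or an amine would read at the same aromatic carbon, and whether a carboxylic acid or a simple alkyl chain on the sulfur would follow either of the two heteroaryl groups.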